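The source may hold more compounds than are shown below. What is called first, only, known or untested is meant among the compounds shown, and "the series" means these compounds.

Working notes on the series

Compound 1 `O=C(Nc1ccc(Oc2ccnc3[nH]ccc23)cc1)c1nn(-c2ccc(Cl)c(F)c2)ccc1=O` and compound 3 `Cn1ccc2c(Oc3ccc(NC(=O)c4nn(-c5ccc(Br)cc5F)ccc4=O)cc3)ccnc21` differ in two places at once, the group on the aromatic nitrogen and the methyl on the shared core; compound 4 `Cn1ccc2c(Oc3ccc(NC(=O)c4nn(-c5ccc(Cl)c(F)c5)ccc4=O)cc3)ccnc21` carries the core of compound 3 together with the aryl group of compound 1.

In a functional assay on PC-3 cells (Homo sapiens) for cytotoxicity, read by MTT assay, with a stated time of 72 h (a higher number here means a weaker inhibitor, a lower number a stronger inhibitor), compound 3 gives 20500 nM, the highest of the two numbers in hand. Compound 1 gives 7780 nM in this assay, a lower number than compound 3, the difference lying beyond the scatter. Compound 2 `COc1ccc(-n2ccc(=O)c(C(=O)Nc3ccc(Oc4ccnc5c4ccn5C)cc3)n2)cc1` gives only a limit in this assay, > 60000 nM, and the limit is the limit of > 60000 nM in this assay, at which 1 of the 3 values shown sits.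

For the measured compounds named here, the one measured step at the aryl position is an at least 2.9-fold lower number from compound 2 to compound 3 (0.46 log units; beyond the scatter). The change to be judged here is 4-chloro-3-fluorophenyl in place of 4-bromo-2-fluorophenyl on an aromatic nitrogen. The related step from compound 2 to compound 3 ran toward a lower number when a dihalophenyl replaced a methoxyphenyl; the present change swaps one dihalophenyl for another, so a smaller movement is expected in this assay, if any beyond the scatter, and more likely downward, since compound 1 with the same aryl gives 7780 nM.

Compound 4 is therefore expected to give about 12000 nM in this assay, between 4000 nM and 40000 nM, a step of a 1.7-fold lower number from compound 3 to compound 4 (0.23 log units; within the scatter).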

Compound 4, half-maximal inhibitory concentration: 32700 nM
The estimate for compound 4 lay 2.7-fold (0.44 log units) below the measured number, within the range that was stated.
By their numbers in this assay, from the lowest: compound 1; then compounds 3 and 4 (each within the scatter of the next). At a limit, above all of these: compound 2.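

In this assay, on the methylated core, the exchange of 4-bromo-2-fluorophenyl for 4-chloro-3-fluorophenyl on the aromatic nitrogen gives a 1.6-fold higher number from compound 3 to compound 4 (0.20 log units; within the scatter) and so does not separate these two dihalophenyl groups, although both the halogen and the placing of the fluorine differ. Compound 2 stands at a limit, so an at least 1.8-fold lower number from compound 2 to compound 4 (0.26 log units; that floor lies within the scatter) is only a floor, and it does not by itself set 4-chloro-3-fluorophenyl apart from 4-methoxyphenyl. For the compounds shown here, with the aryl group now held fixed, the methyl on the aromatic nitrogen of the core can be read alone for the first time, as a 4.2-fold higher number from compound 1 to compound 4 (0.62 log units; beyond the scatter) and the only one of these new steps beyond the scatter.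

Open, from the compounds shown here alone, is whether the methyl step recurs with other aryl groups, and whether a longer chain on that core nitrogen, or an amine or a carboxylic acid on the aryl ring, would move the number in either direction. No measurement given here accounts for the methyl step or for the flat aryl exchange.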